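Amine Substituent Exchange and Antiproliferative Activity

The source may report more compounds than this note shows. Statements on the series, on what has been measured and on what is new or still open speak of the compounds shown alone.

compound 1 `CNC1=CC(=O)c2ccccc2C1=O`: 41400 nM
compound 2 `O=C1C=C(N2CCCC2)C(=O)c2ccccc21`: 111000 nM

In a functional assay on HL-60 cells (Homo sapiens) for antiproliferative activity, read by MTT assay (on this read-out higher numbers stand for weaker inhibition and lower numbers for stronger inhibition), compound 1 gives 41400 nM, while compound 2 gives 111000 nM. Compound 2 therefore stands highest of the two numbers, separated from compound 1 by a 2.7-fold higher number from compound 1 to compound 2 (0.43 log units; beyond the scatter), a step beyond the scatter.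

Compound 3 `O=C1C=C(NCCO)C(=O)c2ccccc21` differs from compound 2 by (2-hydroxyethyl)amino in place of pyrrolidin-1-yl on a double-bonded ring carbon. Among the compounds with values here, the only measured step that bears on this change is a 2.7-fold higher number from compound 1 to compound 2 (0.43 log units; beyond the scatter), where a pyrrolidin-1-yl group replaced a methylamino group on the same double-bonded ring carbon and the number rose modestly. Compound 3 reverses part of that change, bringing back a group with hydrogen-bond donors, so a modest move in the opposite direction is expected, roughly undoing the earlier step.

Compound 3 is therefore estimated at 45000 nM in this assay, with a range of 20000 nM to 110000 nM, which means an expected step of a 2.5-fold lower number from compound 2 to compound 3 (0.39 log units; beyond the scatter).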

Compound 3, half-maximal inhibitory concentration: 49800 nM
The estimate for compound 3 lay 1.1-fold (0.04 log units) below the measured number; the range from low to high includes it.
By their numbers in this assay, from the lowest: compounds 1 and 3 (each within the scatter of the next); then compound 2.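

In this assay, the exchange of pyrrolidin-1-yl for (2-hydroxyethyl)amino on the double-bonded ring carbon gives a 2.2-fold lower number from compound 2 to compound 3 (0.35 log units; beyond the scatter), so the earlier rise at this position is not kept once the ring gives way to an open chain. Hydroxymethyl in place of hydrogen on the saturated chain carbon bound to the amine nitrogen, by contrast, gives a 1.2-fold higher number from compound 1 to compound 3 (0.08 log units; within the scatter), so the two open-chain amines cannot be told apart in this assay. Nothing at hand accounts for either result.

The compounds shown leave open whether the ring itself or the loss of the amine hydrogen sets compound 2 apart, since the two go together here. They also leave open how a piperidine ring, a longer hydroxyalkyl chain or a carboxylic acid at the chain end would behave at this position.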